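Biaryl to Furyl Swap on the Benzylamine Arm

The source may report more compounds than this note shows. Statements on the series, on what has been measured and on what is new or still open speak of the compounds shown alone.

Compound 1 `CN(CC1=CC[C@H]2C[C@@H]1C2(C)C)Cc1ccc(F)cc1` carries the shared core with a fluoro on an aromatic carbon. In an assay on HEK293 cells for displacement of a labelled ligand from C-X-C chemokine receptor type 3 (Homo sapiens) (on this read-out lower numbers stand for stronger inhibition and higher numbers for weaker inhibition), compound 1 gives 6310 nM, a weak result. Compound 2 `CN(CC1=CC[C@H]2C[C@@H]1C2(C)C)Cc1ccc(-c2ccc(Cl)cc2)cc1` has a 4-chlorophenyl in place of that fluoro. For compound 2 this assay reports only a limit, > 316 nM, and no number. The step that the limit leaves unreadable from compound 1 to compound 2 is therefore unreadable because the limit of > 316 nM in this assay, at which 1 of the 2 values shown sits, caps what can be seen on that side; compound 2 stands at the limit, and nothing more is known of its standing.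

Compound 3 `CN(CC1=CC[C@H]2C[C@@H]1C2(C)C)Cc1ccc(-c2ccoc2)cc1` is the next member of the series. Its change from compound 2: furan-3-yl in place of 4-chlorophenyl on an aromatic carbon. Among the compounds with values here, no measured step bears on this change with a readable size; the only measured step is the unreadable one just described. The expectation for compound 3 therefore rests on the weak value of compound 1 and the limit of compound 2, and no direction beyond the scatter can be stated. The expected step is a step that the limit leaves unreadable from compound 2 to compound 3. Compound 3 is estimated at 3000 nM, within a range of 500 nM to 20000 nM, with a real chance that only a limit is reported.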

Compound 3, inhibition constant: 6310 nM
Estimate against measurement, compound 3: 2.1-fold (0.32 log units) below; low and high end bracket the measured number.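

Furan-3-yl in place of fluoro on this aromatic carbon gives the first readable step of the series in this assay: no change at the digits printed from compound 1 to compound 3 (within the scatter). At this position, para to a large group, a five-membered aromatic ring with one hetero atom and one hydrogen-bond acceptor is thus not separated from a lone fluoro, and the added size of the substituent brings no readable gain or loss across this one pair. Compound 2 has only a limit and no number, so neither step involving it can be read, because of what that compound's entry holds: the limit of > 316 nM in this assay, at which 1 of the 3 values shown sits.

On these data alone, whether 4-chlorophenyl truly differs from furan-3-yl or from fluoro at this position remains open, and a number for compound 2 would be needed to settle it. Also open, as far as these compounds go, is whether any group on this aromatic carbon moves the binding value beyond the scatter, for instance a carboxylic acid or a primary amine in place of furan-3-yl, since two compounds with readable values define no trend.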